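A few compounds are considered here, and "the series" means these few. Any claim that something is new, unique, unknown or untested is made for them only; others in the source may bear on it.

Measured in an ADME assay on a cell-free system (plasma, Rattus norvegicus) for protein binding; on this read-out lower numbers stand for a smaller free fraction and higher numbers for a larger free fraction:
- compound 1 `Cc1c(C(F)F)nnc2sc(C(=O)NC3CN(c4ncc(C(F)(F)F)cn4)C3)c(N)c12`: 0.017
- compound 2 `Cc1c(Cl)nnc2sc(C(=O)NC3CN(c4cc(C(F)(F)F)ncc4Cl)C3)c(N)c12`: 0.019

Compound 1 stands level with compound 2, the two numbers lying within the scatter of each other. Compound 3 `Cc1c(CF)nnc2sc(C(=O)NC3CN(c4ncc(C(F)(F)F)cn4)C3)c(N)c12` keeps the rest of compound 1 and changes one group: hydrogen in place of fluoro on a saturated chain carbon bound to an aromatic carbon and a fluorine atom, that is, difluoromethyl to fluoromethyl. For the measured compounds named here, no measured pair shows this change, so the expectation has no direct precedent. The expected step of a 1.4-fold higher number from compound 1 to compound 3 (0.15 log units; within the scatter) is small, towards a larger free fraction, and is not expected to go beyond the scatter. For compound 3 the estimate is 0.024, with an expected range of 0.012 to 0.048.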

Compound 3, unbound fraction: 0.034
For compound 3 the middle estimate is 1.4-fold (0.15 log units) below the measured one, and the stated range covers the measured number.
By their numbers in this assay, from the lowest: compounds 1, 2 and 3 (each within the scatter of the next).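

In this assay, for the compounds shown here, difluoromethyl to fluoromethyl on this saturated chain carbon gives a 2.0-fold higher number from compound 1 to compound 3 (0.30 log units; within the scatter) and so offers the first single-place reading for the series. On this one pair, losing one fluorine does not carry the unbound fraction beyond the scatter. No available data bear on the origin of this step.

Going by these compounds, whether hydroxymethyl or a longer chain such as ethyl at this place would move the unbound fraction beyond the scatter remains open. So does whether the same change reads alike on the core of compound 2.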